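Trifluoromethyl Replacing the Thiophene Ketone on a Chromene Core

The source may report more compounds than this note shows. Statements on the series, on what has been measured and on what is new or still open speak of the compounds shown alone.

Measured compounds:
compound 1, `CC1(C)C=C(n2ccccc2=O)c2cc(C(=O)c3cccs3)ccc2O1`, 5.84
compound 2, `CC1(C)C=C(n2ccccc2=O)c2cc(OCC(=O)c3ccc(F)cc3)ccc2O1`, 4.77
compound 3, `CC1(C)C=C(n2ccccc2=O)c2cc(OC(=O)Nc3ccccc3C(F)(F)F)ccc2O1`, 5.19

Of the compounds shown here, three sharing one core have been tested in a functional assay (trachea) with Rattus norvegicus as the target; on this read-out higher numbers stand for higher potency (the scale is a negative logarithm) and lower numbers for lower potency. Compound 1 stands highest of the three; compound 3 comes nearest, with a number lower by a margin beyond the usual scatter, and compound 2 lies furthest, also beyond the scatter. In this assay compound 1 therefore gives the strongest response of the set.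

Compound 4, `CC1(C)C=C(n2ccccc2=O)c2cc(C(F)(F)F)ccc2O1`, has not yet been measured. It differs from compound 1 in one place:

trifluoromethyl in place of (thiophen-2-yl)carbonyl on an aromatic carbon

For the measured compounds named here, no single-point step between two measured compounds is available to guide the expectation. The two compounds that carry groups other than the (thiophen-2-yl)carbonyl at this position, compound 2 and compound 3, both sit below compound 1 in this assay, so the step from compound 1 to compound 4 is expected to run downward by a moderate amount, a number 0.54 log units lower from compound 1 to compound 4 (beyond the scatter). Compound 4 is accordingly expected to give about 5.3, within a range from 4.6 to 6.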

Compound 4, logarithm of the reciprocal of the active concentration, log(1/C): 7.37
Compound 4: middle estimate off by 2.07 log units, on the low side; measured number outside the range, above it.
By their numbers in this assay, from the lowest: compound 2; then compound 3; then compound 1; then compound 4.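

In this assay, placing trifluoromethyl on this aromatic carbon in place of (thiophen-2-yl)carbonyl gives a number 1.53 log units higher from compound 1 to compound 4 (beyond the scatter). The response at this position therefore depends on neither the five-membered aromatic ring nor the carbonyl, since compound 4 carries neither and still gives 7.37, with fewer heavy atoms and no hydrogen-bond acceptors in the entering group. No measurement shown here accounts for this rise.

Because the ring, the carbonyl and the linking carbon all leave in one change while the fluorines enter, the compounds shown do not separate what each contributes to the step. As far as these compounds go, it also remains open how a nitrile, a methyl group or a chlorine atom on this aromatic carbon would stand against trifluoromethyl on the same core.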